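Heteroaryl in place of the aryl in a ceramidase inhibitor

The source may hold more compounds than are shown below. What is called first, only, known or untested is meant among the compounds shown, and "the series" means these compounds.

Measured compounds
compound 1 `O=c1[nH]cc(-c2ccccc2)o1` — "not active" (no number reported)
compound 2 `COc1cc(-c2cn(C(=O)NCCCCc3ccccc3)c(=O)o2)ccc1F` — 80 nM

Going by the values given here, in an assay on isolated protein for inhibition of acid ceramidase (Homo sapiens), read by LC-MS, with a stated time of 1 h (a higher number here means a weaker inhibitor, a lower number a stronger inhibitor), compound 2 gives 80 nM, the only number in the set. Among the compounds with values here, compound 1 is reported in this assay as "not active" (no number reported) with no number, so no step between compound 1 and compound 2 can be sized. Compound 3 `O=C(NCCCCc1ccccc1)n1cc(-c2cscn2)oc1=O` differs from compound 2 by 1,3-thiazol-4-yl in place of 4-fluoro-3-methoxyphenyl on an aromatic carbon. Within the data shown here, no step of this kind has been measured in the set. The expected step of a 3.8-fold higher number from compound 2 to compound 3 (0.57 log units; beyond the scatter) is toward weaker inhibition and beyond the usual scatter. For compound 3 the estimate is 300 nM, with a range from 60 nM to 2000 nM.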

Compound 3, half-maximal inhibitory concentration: 44 nM
Compound 3: middle estimate off by 6.8-fold (0.83 log units), on the high side; the whole stated range lies above it.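

In this assay, 1,3-thiazol-4-yl in place of 4-fluoro-3-methoxyphenyl gives a 1.8-fold lower number from compound 2 to compound 3 (0.26 log units; within the scatter), a step within the scatter. This aromatic carbon of the shared core therefore accepts a five-membered aromatic ring with 2 hetero atoms and fewer heavy atoms, and neither the fluorine nor the methoxy group is needed to stay in this range. No measurement on hand explains why the two groups read alike.

Still open, as far as these compounds go, is whether a pyridyl group, an aminomethyl group or a carboxylic acid on this carbon would hold up. Also open, from the compounds shown here alone, is whether 1,3-thiazol-2-yl would read the same as 1,3-thiazol-4-yl.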